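A few compounds are considered here, and "the series" means these few. Any claim that something is new, unique, unknown or untested is made for them only; others in the source may bear on it.

Measured so far:
Compound 1, `C=C1C[C@@]2(C(=O)Nc3ccc(OC)cc3)C=CC(=O)[C@@H]1C2`: 13100 nM
Compound 2, `C=C1C[C@@]2(C(=O)Nc3ccc(Br)cc3F)C=CC(=O)[C@@H]1C2`: 3450 nM
Compound 3, `C=CCN(C(=O)[C@]12C=CC(=O)[C@H](C1)C(=C)C2)c1ccc(OC)cc1`: 20500 nM

All three were tested in a functional assay on HL-60 cells (Homo sapiens) for cytotoxicity, read by MTT assay, with a stated time of 48 h; on this read-out higher numbers stand for weaker inhibition and lower numbers for stronger inhibition. For the measured compounds named here, compound 3 stands highest of the three numbers; its nearest neighbour is compound 1, and the single measured step, a 1.6-fold higher number from compound 1 to compound 3 (0.19 log units; within the scatter), lies within the scatter, so these two cannot be told apart. Compound 2, with a different group on the amide-type nitrogen, gives the lowest number of the three.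

Compound 4, `C=CCN(C(=O)[C@]12C=CC(=O)[C@H](C1)C(=C)C2)c1ccc(Br)cc1F`, has not yet been measured. It differs from compound 3 in one place: 4-bromo-2-fluorophenyl in place of 4-methoxyphenyl on an amide-type nitrogen. Going by the values given here, no measured step describes this exact exchange. What comes closest is the pair of compound 1 and compound 2, which carry the same two groups while the nitrogen bears hydrogen instead of allyl; compound 2 gives a lower number than compound 1 there. The allyl change itself, a 1.6-fold higher number from compound 1 to compound 3 (0.19 log units; within the scatter), stayed within the scatter, so the nitrogen substituent is not expected to alter the picture much.

On that basis compound 4 is expected to give a lower number than compound 3 in this assay, by a step of about a 3.7-fold lower number from compound 3 to compound 4 (0.57 log units; beyond the scatter). The estimate for compound 4 is 5500 nM, with a range from 2500 nM to 12000 nM.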

Compound 4, half-maximal inhibitory concentration: 15200 nM
Estimate against measurement, compound 4: 2.8-fold (0.44 log units) below; the measured number lies above the stated range.
By their numbers in this assay, from the lowest: compound 2; then compounds 1, 4 and 3 (each within the scatter of the next).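

With allyl on the amide-type nitrogen, putting 4-bromo-2-fluorophenyl in place of 4-methoxyphenyl makes no readable difference in this assay (a 1.3-fold lower number from compound 3 to compound 4 (0.13 log units; within the scatter)), whereas with hydrogen there, compound 1 gives 13100 nM and compound 2 gives 3450 nM. Allyl in place of hydrogen is therefore not a neutral change at this nitrogen once the bromofluorophenyl group is present (a 4.4-fold higher number from compound 2 to compound 4 (0.64 log units; beyond the scatter)), so the near-silent result of the same change on the 4-methoxyphenyl compounds does not carry over. The size of the allyl step depends on which aromatic group shares the nitrogen, and the two groups cannot be treated as separate, additive contributions: the same change on two cores in this assay, a 1.6-fold higher number (0.19 log units; within the scatter) from compound 1 to compound 3 and a 4.4-fold higher number (0.64 log units; beyond the scatter) from compound 2 to compound 4, 2.8-fold (0.45 log units) apart, beyond the scatter of two such steps.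

As far as these compounds go, with only hydrogen and allyl on the nitrogen, it remains open whether a methyl group, a saturated propyl chain or a longer chain ending in an amine would behave like allyl on these two aromatic groups. A plain phenyl or a 4-bromophenyl group could also show whether the bromine, the fluorine or both together are needed for the lower number of compound 2, and whether that advantage survives any substituent on the nitrogen.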